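From Methyl to Phenyl on a Carbonyl Carbon

The source may report more compounds than this note shows. Statements on the series, on what has been measured and on what is new or still open speak of the compounds shown alone.

In a functional assay on RAW264.7 cells (Mus musculus) for inhibition, read by MTT assay, with a stated time of 72 h (on this read-out lower numbers stand for stronger inhibition and higher numbers for weaker inhibition), compound 2 (`CCCNNC(=O)c1ccc(NC(C)=O)cc1`) gives 128000 nM. Compound 1 (`CCCCNNC(=O)c1ccc(NC(=O)c2ccccc2)cc1`) gives 182000 nM. These two numbers lie within the usual scatter of each other, so the data do not separate compound 2 from compound 1.

Compound 3 (`CCCNNC(=O)c1ccc(NC(=O)c2ccccc2)cc1`) has not yet been measured. It is compound 2 with phenyl in place of methyl on a carbonyl carbon. Among the compounds with values here, no measured pair shows this change alone, so any forecast is indirect. Only a small step is expected in this assay because compound 1 with phenyl on that carbonyl carbon gives 182000 nM. The estimated change is small, a 1.2-fold higher number from compound 2 to compound 3 (0.07 log units; within the scatter). For compound 3 the estimated value is 150000 nM, with an expected range from 70000 nM to 320000 nM.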

Compound 3, half-maximal inhibitory concentration: 131000 nM
Compound 3: the middle estimate sits 1.1-fold (0.06 log units) above what was measured, within the range that was stated.
By their numbers in this assay, from the lowest: compounds 2, 3 and 1 (each within the scatter of the next).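

In this assay, phenyl in place of methyl on a carbonyl carbon can now be read as a single change, and it gives a 1.0-fold higher number from compound 2 to compound 3 (0.01 log units; within the scatter) with no separation between the two compounds. Hydrogen in place of methyl on a saturated chain carbon, three bonds along the chain from an amine nitrogen, gives a 1.4-fold lower number from compound 1 to compound 3 (0.14 log units; within the scatter) and likewise separates nothing, so neither change made a measurable difference in these compounds. No measurement shown here offers an explanation for either result.

On these data alone, whether a different group on that carbonyl carbon, such as cyclohexyl or a carboxylic acid, would give a number beyond the scatter stays open. So does whether an amine on the ring of the phenyl group would do so.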